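Oxamide series: pentyl ester, acid, carboxymethyl ester, hydrazide

A few compounds are considered here, and "the series" means these few. Any claim that something is new, unique, unknown or untested is made for them only; others in the source may bear on it.

Measured so far in a functional assay on the whole organism (strain Sprague-Dawley CD) for inhibition, with Rattus norvegicus as the target, read by paw edema, at a dose of 10 mg/kg by the intraperitoneal route; on this read-out higher numbers stand for a stronger effect at the one dose given and lower numbers for a weaker effect:
- compound 1, `CCCCCOC(=O)C(=O)Nc1cccccc1=O`, 61%
- compound 2, `O=C(O)C(=O)Nc1cccccc1=O`, 89%; 70% (2 entries)
- compound 3, `O=C(O)COC(=O)C(=O)Nc1cccccc1=O`, 66%

Compound 3 is the carboxymethyl ester of the shared core. Among the measured compounds shown here, on the single numbers, compound 3 gives 66% in this assay and compound 1 gives 61%; a number 5 percentage points higher from compound 1 to compound 3 (within the scatter). For the measured compounds named here, compound 2 adds (the several entries of compound 2 in this assay, 89%; 70% (2 entries)), two entries rather than one number, so no step to it is drawn.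

Compound 4, `NNC(=O)C(=O)Nc1cccccc1=O`, is to be measured in this assay. It differs from compound 3 at the carbonyl carbon: aminoamino in place of carboxymethoxy on a carbonyl carbon. Going by the values given here, only one measured step changes the same place, a number 5 percentage points higher from compound 1 to compound 3 (within the scatter), and it did not move the read-out beyond the scatter; compound 2, with the free acid at that carbon, shows 89%; 70% (2 entries) across its two entries. Over butyl, carboxymethyl and acid at this carbonyl carbon the numbers therefore sit in a narrow band, and no step beyond the scatter is expected for aminoamino in place of carboxymethoxy.

The expected step is a number 4 percentage points higher from compound 3 to compound 4 (within the scatter). Compound 4 is estimated at 70%, with a range from 50% to 88%.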

Compound 4, a percentage reported as inhibition, in the whole organism at one dose (the size of the read-out at that dose, not a potency): 64%
Compound 4: middle estimate off by 6 percentage points, on the high side; the range from low to high includes it.
By their numbers in this assay, from the lowest: compounds 1, 4 and 3 (each within the scatter of the next).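

Aminoamino in place of carboxymethoxy on a carbonyl carbon is the first change in the series that puts a nitrogen-bound group at this carbon where the earlier esters carry an oxygen-bound one, and in this assay it gives a number 2 percentage points lower from compound 3 to compound 4 (within the scatter). The comparison with the pentyl ester, aminoamino in place of pentyloxy, reads the same way: a number 3 percentage points higher from compound 1 to compound 4 (within the scatter). At the one dose given, the read-out therefore does not separate the hydrazide from either ester, whether the ester group ends in a carboxy group or in a plain chain, and among compound 1, compound 3 and compound 4 nothing goes against this.

Open, from the compounds shown here alone, is whether a plain amino group, a dimethylamino group or a longer chain on the nitrogen of this carbonyl carbon would also stay within the scatter of compound 4, and whether this sameness at one dose would hold at other doses. Compound 2, the free acid, cannot be set against compound 4 as a single number in this assay, and it stays outside this reading: the several entries of compound 2 in this assay, 89%; 70% (2 entries)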